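The source may report more compounds than this note shows. Statements on the series, on what has been measured and on what is new or still open speak of the compounds shown alone.

Measured so far:
compound 1, `COc1cc(-n2ncnc2-c2ccc(OC(C)C)cc2)cc(OC)c1OC`, 600 nM
compound 2, `COc1cc(-c2ncnn2-c2ccc(Cl)c(Cl)c2)cc(OC)c1OC`, > 10000 nM
compound 3, `COc1cc(-c2ncnn2-c2ccc(F)cc2)cc(OC)c1OC`, > 10000 nM

Going by the values given here, in a functional assay on HeLa cells (Homo sapiens) for antiproliferative activity, read by MTT assay, with a stated time of 72 h (a lower number here means a stronger inhibitor, a higher number a weaker inhibitor), compound 1 gives 600 nM and is the only member of the series with a number. Compound 2 reaches only the assay limit, > 10000 nM. Compound 3 likewise reaches only the limit, > 10000 nM. Among the compounds with values here, both limits sit at the limit of > 10000 nM in this assay, at which 2 of the 3 values shown sit, so the single measured step, a step that the two limits leave unreadable from compound 2 to compound 3, cannot be read.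

Compound 4, `COc1cc(-n2ncnc2-c2ccccc2)cc(OC)c1OC`, differs from compound 1 by hydrogen in place of isopropoxy on an aromatic carbon. No measured step touches this place on the ring: the one step that is shown concerns a different position and is unreadable, and compounds 2 and 3 also carry the triazole attached through a different atom. The expectation for compound 4 therefore rests on compound 1 alone. Removal of the isopropoxy, a group of four heavy atoms, is expected to cost some activity, so a step of a 2.5-fold higher number from compound 1 to compound 4 (0.40 log units; beyond the scatter) is estimated, in the weakening direction but near the edge of the scatter. Compound 4 is estimated at 1500 nM, with a range from 400 nM to 6000 nM.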

Compound 4, half-maximal inhibitory concentration: > 10000 nM
Compound 4 gave a limit, no number; the forecaster's own chance of this, stated with the estimate: 20%; middle value at least 6.6-fold (0.82 log units) away from the limit.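

Going by these compounds alone, replacing isopropoxy with hydrogen, on the aromatic carbon para to a large group, gives an at least 16-fold higher number from compound 1 to compound 4 (1.22 log units; beyond the scatter) in this assay, the first readable step. Within the data shown here, compound 4 gives only a limit, not a number, and joins the other compounds sitting there: the limit of > 10000 nM in this assay, at which 3 of the 4 values shown sit. Among the two compounds joined by this step, the measurable activity is therefore present only with the isopropoxy in this place, a dependence that the earlier compounds could not show.

As far as these compounds go, whether a methoxy, a hydroxyl, an amine or a longer alkoxy chain in this place would retain activity remains open. Compound 2 and compound 3 differ from compound 1 in more than one place and the step between them cannot be read, so the contribution of other parts of the structure also stays unresolved.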